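Cyclohexyl for Butyl on the Alkyne Arm

This account rests on a few compounds, and the source may have more. Where it says the series, first, only, none or still open, it means among the compounds named here.

compound 1 `CC(=O)Nc1nc(-c2cccc(NS(=O)(=O)c3ccc(Br)cc3)c2)cs1` — 19.7%
compound 2 `CCCCC#Cc1ccc(S(=O)(=O)Nc2cccc(-c3csc(NC(C)=O)n3)c2)cc1` — 9.3%

In a functional assay on A-375 cells (Homo sapiens) for antiproliferative activity, read by trypan blue exclusion, with a stated time of 48 h, tested at 5 uM (on this read-out lower numbers stand for a stronger effect and higher numbers for a weaker effect at the one concentration tested), compound 2 gives 9.3%, the lower of the two numbers, and compound 1 gives 19.7%. Among the compounds with values here, the only measured step, a number 10.4 percentage points lower from compound 1 to compound 2 (beyond the scatter), concerns the arm on which the next change sits. Compound 3 `CC(=O)Nc1nc(-c2cccc(NS(=O)(=O)c3ccc(C#CC4CCCCC4)cc3)c2)cs1` differs from compound 2 in one place: cyclohexyl in place of butyl on a triple-bonded carbon. Within the data shown here, no measured step exchanges a chain for a ring at that spot, so the step is expected to be a number 1.3 percentage points lower from compound 2 to compound 3 (within the scatter), not beyond the scatter. Compound 3 is therefore estimated at 8%, with a range from 2% to 18%.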

Compound 3, a percentage reported as activity, at one concentration (the size of the read-out at that concentration, not a potency): 1.2%
Compound 3: the middle estimate sits 6.8 percentage points above what was measured; the whole stated range lies above it.
By their numbers in this assay, from the lowest: compounds 3 and 2 (each within the scatter of the next); then compound 1.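

In this assay the exchange of butyl for cyclohexyl on the triple-bonded carbon reads as a number 8.1 percentage points lower from compound 2 to compound 3 (within the scatter) and so shows that a six-membered carbon ring can stand at this spot as well as an open chain. The exchange of bromo for 2-cyclohexylethynyl reads as a number 18.5 percentage points lower from compound 1 to compound 3 (beyond the scatter) and so gives a second alkyne arm, after hex-1-yn-1-yl, that lies beyond the scatter from bromo. Nothing available explains these numbers. As far as these compounds go, whether a phenyl ring or an amine on the triple-bonded carbon would hold the number this low stays open.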